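The source may report more compounds than this note shows. Statements on the series, on what has been measured and on what is new or still open speak of the compounds shown alone.

Measured compounds:
compound 1 `O=Cc1ccc(-c2cn3ccnc3c(-c3ccc4ncn(C5CCCCC5)c4c3)n2)cc1` with 51.2%
compound 2 `Fc1ccc(-c2cn3ccnc3c(-c3ccc4ncn(C5CCCCC5)c4c3)n2)cc1` with 15.8%
compound 3 `c1cn2cc(-c3ccsc3)nc(-c3ccc4ncn(C5CCCCC5)c4c3)c2n1` with 1.35%

In a functional assay on MDA-MB-231 cells (Homo sapiens) for inhibition, read by sulforhodamine B assay, with a stated time of 48 h, tested at 10 uM (a lower number here means less inhibition, a higher number more inhibition at the concentration tested (going by the name of the read-out)), compound 3 gives 1.35%, the lowest of the three numbers; its steps to compound 2 and to compound 1 are both beyond the scatter, so its inhibition in this assay is lower than that of the other two. The compound now to be considered is compound 4 `Brc1ccc(-c2cn3ccnc3c(-c3ccc4ncn(C5CCCCC5)c4c3)n2)cc1`, which shares the core of compound 3 and differs from it in one place: 4-bromophenyl in place of thiophen-3-yl on an aromatic carbon.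

Going by the values given here, two measured steps bear on this change. The closest is a number 14.5 percentage points lower from compound 2 to compound 3 (beyond the scatter), which runs in the opposite direction: a para-halophenyl gave way to thiophen-3-yl and the inhibition fell by a modest amount. Among the compounds with values here, compound 4 reverses that sense, putting a para-halophenyl back, though with bromine rather than fluorine, and no measured pair shows what that exchange alone does. The other step, a number 49.9 percentage points lower from compound 1 to compound 3 (beyond the scatter), was large, but formyl is far from bromine and it is a weaker guide. A modest rise is therefore expected in this assay, roughly undoing the drop from compound 2 to compound 3, with wide uncertainty on the halogen.

The estimated step is a number 16.7 percentage points higher from compound 3 to compound 4 (beyond the scatter). Compound 4 is expected to give 18%, in the range 3% to 40%.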

Compound 4, a percentage reported as inhibition, at one concentration (the size of the read-out at that concentration, not a potency): 22.8%
Compound 4: the middle estimate sits 4.8 percentage points below what was measured; measured number inside the range.
By their numbers in this assay, from the lowest: compound 3; then compounds 2 and 4 (each within the scatter of the next); then compound 1.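

In this assay, going by these compounds alone, the exchange of one halogen for the other, which no earlier pair could show, gives a number 7 percentage points higher from compound 2 to compound 4 (within the scatter) and so does not separate 4-bromophenyl from 4-fluorophenyl on this aromatic carbon of the shared core. The return from thiophen-3-yl to a halogen-bearing phenyl ring now has a direct reading, a number 21.5 percentage points higher from compound 3 to compound 4 (beyond the scatter) and beyond the scatter, so compound 2 and compound 4 both stand clear of the thiophene compound, compound 3. The formyl compound also stays apart with the second halogen, as a number 28.4 percentage points lower from compound 1 to compound 4 (beyond the scatter) is beyond the scatter, so among these compounds the formyl-bearing phenyl ring gives more inhibition than either halogen-bearing one at the concentration tested.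

From the compounds shown here alone, it remains open whether the higher number of compound 1 is tied to the formyl group itself or would also appear with a carboxylic acid, a nitrile or an amine on the same phenyl ring. Going by these compounds, it is equally open whether thiophen-3-yl falls short as a five-membered ring or as the group without a substituent, a question that unsubstituted phenyl or thiophene bearing a bromo group would address. The data given here include no independent measurement that would explain these differences.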